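Chloro for Methyl on the Pyridine-Bearing Core

The source may report more compounds than this note shows. Statements on the series, on what has been measured and on what is new or still open speak of the compounds shown alone.

Compound 1 `Cc1ccc(-c2cc3n(n2)CCCC3)nc1` carries a methyl group on its six-membered nitrogen ring; in a functional assay on HEK293 cells for negative allosteric modulation of metabotropic glutamate receptor 5 (Rattus norvegicus), read by FLIPR and calcium flux, with a stated time of 170 s (a lower number here means a stronger inhibitor, a higher number a weaker inhibitor), compound 1 gives 3000 nM. Compound 2 `Clc1ccc(-c2cc3n(n2)CCCC3)nc1` differs from it in one place, (chloro in place of methyl on an aromatic carbon), and in this assay compound 2 gives 669 nM, so that a 4.5-fold lower number from compound 1 to compound 2 (0.65 log units; beyond the scatter). Compound 3 `Cc1cccc(-c2cc3n(n2)CCCC3)n1` has the same atoms as compound 1 joined differently; the difference between the two cores is not broken down here. In this assay, going by the values given here, compound 3 gives 1240 nM, a number within the usual scatter of the one for compound 2.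

Compound 4 `Clc1cccc(-c2cc3n(n2)CCCC3)n1` is not yet measured. It differs from compound 3 in one place, (chloro in place of methyl on an aromatic carbon). This is the same kind of change as between compound 1 and compound 2, but not the same: here the aromatic carbon lies next to the ring nitrogen and meta to a group of 9 heavy atoms, whereas before it lay two atoms from the ring nitrogen and para to that group. In this assay the estimated step is a 2.8-fold lower number from compound 3 to compound 4 (0.44 log units; beyond the scatter), a little smaller than the measured one because a 4.5-fold lower number from compound 1 to compound 2 (0.65 log units; beyond the scatter) rests on a different place. Compound 4 is therefore expected to give about 450 nM, with a likely range from 150 nM to 1300 nM.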

Compound 4, half-maximal inhibitory concentration: 1520 nM
Compound 4: the middle estimate sits 3.4-fold (0.53 log units) below what was measured; measured number outside the range, above it.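

In this assay, placing chloro where methyl stood next to the ring nitrogen gives a 1.2-fold higher number from compound 3 to compound 4 (0.09 log units; within the scatter), so this change leaves the number essentially where it was on this core. The same swap therefore does not carry over unchanged from one core to the other: the same change on two cores in this assay, a 4.5-fold lower number (0.65 log units; beyond the scatter) from compound 1 to compound 2 and a 1.2-fold higher number (0.09 log units; within the scatter) from compound 3 to compound 4, 5.5-fold (0.74 log units) apart, beyond the scatter of two such steps This shows that a step measured on one core cannot simply be added to another in this series, yet two pairs are too few to form a rule, and they do not show why the outcomes part.

The compounds shown carry only methyl or chloro on the six-membered aromatic ring, so it remains open how a fluoro, a methoxy or a nitrile group would fare on either core. Also open, from the compounds shown here alone, is whether the difference between the two cores would persist with a bromo or a trifluoromethyl group in place of the chloro.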